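Urea to benzamide on a shared pyrazole-bearing core

The source may report more compounds than this note shows. Statements on the series, on what has been measured and on what is new or still open speak of the compounds shown alone.

The series is compared in a functional assay on 786-0 cells (Homo sapiens) for inhibition, read by sulforhodamine B assay, with a stated time of 48 h; a higher number here means a weaker inhibitor of growth, a lower number a stronger inhibitor of growth. Compound 1, `O=C(Nc1cccc(-n2cc(-c3ccncc3)c(-c3ccc(Cl)c(O)c3)n2)c1)Nc1ccc(Cl)c(Cl)c1`, gives only a limit of the assay, > 32500 nM, (the limit of > 32500 nM in this assay, at which 1 of the 3 values shown sits). Compound 2, `O=C(Nc1cccc(-n2cc(-c3ccncc3)c(-c3ccc(Cl)c(O)c3)n2)c1)Nc1cc(C(F)(F)F)cc(C(F)(F)F)c1`, gives 3160 nM. Compound 3, `COc1cc(-c2nn(-c3cccc(NC(=O)Nc4cccc(C(F)(F)F)c4)c3)cc2-c2ccncc2)ccc1Cl`, gives 4050 nM, the higher of the two numbers shown, and the gap to compound 2 lies within the scatter, so the two read as alike. Among the measured compounds shown here, no step between measured compounds that differ in one place is available here.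

Compound 4, `COc1cc(-c2nn(-c3cccc(NC(=O)c4ccccc4)c3)cc2-c2ccncc2)ccc1Cl`, has not been measured. It differs from compound 3 at the carbonyl carbon, where (phenyl in place of (3-(trifluoromethyl)phenyl)amino on a carbonyl carbon). For the measured compounds named here, since no measured step covers this kind of change, the expectation rests on the general observation that the group on the far side of the carbonyl decides the outcome, as compound 1 at its limit and compound 2 at its number show. Compound 4 is expected to be a weaker inhibitor of growth than compound 3, with a step from a 3.0-fold higher number from compound 3 to compound 4 (0.47 log units; beyond the scatter) that goes beyond the scatter. For compound 4 an estimated value of 12000 nM is given, with a range from 3500 nM to 40000 nM.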

Compound 4, concentration for total growth inhibition: > 100000 nM
Compound 4: only a limit was reported; the forecaster's own chance of this, stated with the estimate: 25%; at least 8.3-fold (0.92 log units) between middle value and limit.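

Compound 4 in this assay stands only as a limit, not as a number: the limit of > 100000 nM in this assay, at which 1 of the 4 values shown sits. Phenyl in place of (3-(trifluoromethyl)phenyl)amino on a carbonyl carbon, whose other neighbour is an amide-type nitrogen, gives the first step here between two compounds that differ in one place, an at least 24-fold higher number from compound 3 to compound 4 (1.39 log units; beyond the scatter), so on the shared core this position can decide much of the growth inhibition read in this assay. The group that leaves carries both a nitrogen with a hydrogen-bond donor and a trifluoromethyl group, whereas phenyl carries neither, so this single step changes both features at once and cannot assign the outcome to either of them.

What the compounds shown leave open is which of the two features matters, since plain phenylamino on the carbonyl carbon would keep the nitrogen without the trifluoromethyl group, while 3-(trifluoromethyl)phenyl would keep the trifluoromethyl group without the nitrogen. As far as these compounds go, how far the position tolerates other kinds of group, such as a benzylamino group or a longer alkyl chain, also remains unknown.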